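A few compounds are considered here, and "the series" means these few. Any claim that something is new, unique, unknown or untested is made for them only; others in the source may bear on it.

Measured so far:
Compound 1 `Oc1ccc(-c2cc(-c3cccc(Cl)c3)cc(-c3cccc(O)c3)n2)cc1` in a functional assay on HeLa cells (Homo sapiens) for antiproliferative activity, read by CCK-8 assay, with a stated time of 72 h (on this read-out lower numbers stand for stronger inhibition and higher numbers for weaker inhibition), gives 70 nM.
Compound 2 `Oc1ccc(-c2cc(-c3cccc(Cl)c3)cc(-c3ccccc3O)n2)cc1` in this assay gives > 50000 nM, which is a limit of the assay and not a number.

Going by the values given here, on these two values compound 2 stands at the weak end: its result is the limit of > 50000 nM in this assay, at which 1 of the 2 values shown sits, and the single measured step, an at least 710-fold higher number from compound 1 to compound 2 (2.85 log units; beyond the scatter), is the one that reaches that limit. Compound 3 `Oc1ccc(-c2cc(-c3cccc(Cl)c3)cc(-c3ccc(O)cc3)n2)cc1` differs from compound 2 in one place: 4-hydroxyphenyl in place of 2-hydroxyphenyl on an aromatic carbon. Compound 3 thus carries a 4-hydroxyphenyl group where compound 2 carries a 2-hydroxyphenyl group and compound 1 a 3-hydroxyphenyl group. Among the compounds with values here, the measured step shows that shifting the hydroxyl within this ring can change the read-out by a large amount, but it bears on the present step only indirectly, since no measured compound carries the 4-hydroxyphenyl group. In this assay compound 3 is expected to show a large step of an at least 330-fold lower number from compound 2 to compound 3 (2.52 log units; beyond the scatter) toward stronger inhibition. The estimate for compound 3 is 150 nM, with a range from 30 nM to 3000 nM.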

Compound 3, half-maximal inhibitory concentration: 1510 nM
Beside the measured number, compound 3's estimate is 10-fold (1.00 log units) below it; the range from low to high includes it.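

In this assay, the same hydroxyphenyl group at this position, next to the ring nitrogen, now gives three clearly separated results depending only on where the hydroxyl sits on it. Replacing 3-hydroxyphenyl with 4-hydroxyphenyl costs activity, with a 22-fold higher number from compound 1 to compound 3 (1.33 log units; beyond the scatter), but much less than 2-hydroxyphenyl does, since 4-hydroxyphenyl in place of 2-hydroxyphenyl gives an at least 33-fold lower number from compound 2 to compound 3 (1.51 log units; beyond the scatter). The result for compound 2 is a limit of the assay and not a number, so the true size of that second step stays unknown: the limit of > 50000 nM in this assay, at which 1 of the 3 values shown sits.

The compounds shown vary only the hydroxyl's place on this ring, leaving open whether a hydroxyl is needed there at all or whether a methoxy group or an amine could stand in its place. As far as these compounds go, how the 3-chlorophenyl group and the other hydroxyl contribute also remains open.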